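This account rests on a few compounds, and the source may have more. Where it says the series, first, only, none or still open, it means among the compounds named here.

In an ADME assay on microsomes from liver (Mus musculus, strain Balb/c) for metabolic stability, read by LC-MS, with a stated time of 30 min, tested at 10 uM (a higher number here means that more of the compound is left, a lower number that less of the compound is left), compound 1 (`CS(=O)(=O)N1CCCN(S(=O)(=O)c2ccc(CN)s2)CC1`) gives 37%, and compound 2 (`NCc1ccc(S(=O)(=O)c2cccc(S(=O)(=O)N3CCCC3)c2)s1`) gives 59%. That makes compound 2 the higher of the two, by a gap beyond the usual scatter of repeated measurements. Compound 3 (`NCc1ccc(S(=O)(=O)c2cccc(S(=O)(=O)N3CCC[C@H]3CO)c2)s1`) has not yet been measured. It differs from compound 2 in one place, where pyrrolidin-1-yl becomes 2-(hydroxymethyl)pyrrolidin-1-yl: hydroxymethyl in place of hydrogen on a saturated ring carbon, next to the ring nitrogen (hydroxymethyl in place of hydrogen on a saturated ring carbon). Going by the values given here, no measured pair of compounds shows what such a change does, so the starting point is simply compound 2 at 59%. A small downward step is expected in this assay, possibly no larger than the scatter. The estimated change is a number 7 percentage points lower from compound 2 to compound 3 (within the scatter). For compound 3 the expected value is 52%, with an estimated range from 35% to 70%.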

Compound 3, percent of the compound remaining: 63%
For compound 3 the middle estimate is 11 percentage points below the measured one, within the range that was stated.
By their numbers in this assay, from the lowest: compound 1; then compounds 2 and 3 (each within the scatter of the next).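

In this assay, putting hydroxymethyl in place of hydrogen on a saturated ring carbon, next to the ring nitrogen, gives a number 4 percentage points higher from compound 2 to compound 3 (within the scatter). This is the first step shown at this position, and it means that compounds 2 and 3 cannot be told apart in this read-out, even though the entering group brings one hydrogen-bond donor and one hydrogen-bond acceptor. Nothing available gives a reason for this result.

The compounds shown leave open whether a different group on this ring carbon, such as an amine, a carboxylic acid or a longer chain ending in hydroxyl, would also stay within the scatter of compound 2. They also leave open whether hydroxymethyl would give a similar result on the opposite face of the ring.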